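Aryl swaps on the nitrogen in a weakly active series

The compounds below may be only part of what the source reports. "The series", "measured", "known", "first", "only" and "open" are said of these compounds alone.

Measured in a functional assay on MDA-MB-468 cells (Homo sapiens) for antiproliferative activity, read by MTT assay, with a stated time of 24 h; a lower number here means a stronger inhibitor, a higher number a weaker inhibitor:
- compound 1 `CNC(=O)c1ccccc1Oc1nc(Nc2ccc(Br)cc2)ncc1Br`: 36600 nM
- compound 2 `CNC(=O)c1ccccc1Oc1nc(Nc2cccc(Br)c2)ncc1Br`: 31900 nM
- compound 3 `CNC(=O)c1ccccc1Oc1nc(Nc2ccccc2OC)ncc1Br`: > 50000 nM (a limit of the assay, not a number)

Compound 3 gives only a limit, and it stands at the limit of > 50000 nM in this assay, at which 1 of the 3 values shown sits. The next compound is compound 4 `CNC(=O)c1ccccc1Oc1nc(Nc2ccc(C)cc2C)ncc1Br`, which carries 2,4-dimethylphenyl in place of 2-methoxyphenyl on a nitrogen on an aromatic ring.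

For the measured compounds named here, three measured steps bear on this change, all at the same place. Compound 2 carries 3-bromophenyl in place of 4-bromophenyl, which gives a 1.1-fold lower number from compound 1 to compound 2 (0.06 log units; within the scatter). The 2-methoxyphenyl group gives an at least 1.3-fold higher number from compound 1 to compound 3 (0.13 log units; that floor lies within the scatter) against 4-bromophenyl and an at least 1.5-fold higher number from compound 2 to compound 3 (0.19 log units; that floor lies within the scatter) against 3-bromophenyl. Those last two are floors only.

None of the three steps exceeds the scatter, so no step beyond the scatter is expected in this assay. The estimated change is an at least 1.1-fold lower number from compound 3 to compound 4 (0.07 log units; that floor lies within the scatter). Compound 4 is estimated at 42000 nM, with an expected range of 22000 nM to 80000 nM.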

Compound 4, half-maximal inhibitory concentration: 40700 nM
Compound 4: the middle estimate sits 1.0-fold (0.01 log units) above what was measured, and the stated range covers the measured number.
By their numbers in this assay, from the lowest: compounds 2, 1 and 4 (each within the scatter of the next). At a limit, above all of these: compound 3.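

In this assay, the step to 2,4-dimethylphenyl reads a 1.3-fold higher number from compound 2 to compound 4 (0.11 log units; within the scatter) and a 1.1-fold higher number from compound 1 to compound 4 (0.05 log units; within the scatter), so an aryl group with only carbon and hydrogen on it sits within the scatter of both bromophenyl groups. The step from the 2-methoxyphenyl compound, an at least 1.2-fold lower number from compound 3 to compound 4 (0.08 log units; that floor lies within the scatter), is a floor only and gives no size for this change. Compound 3 stays a limit of the assay and not a number: the limit of > 50000 nM in this assay, at which 1 of the 4 values shown sits.

The compounds shown do not separate the contributions of the two methyl groups of 2,4-dimethylphenyl. On these data alone, it also stays open whether an aryl group carrying an amine or a carboxylic acid on this nitrogen, or any change elsewhere on the shared core, would move the number beyond the scatter.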